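The source may hold more compounds than are shown below. What is called first, only, known or untested is meant among the compounds shown, and "the series" means these compounds.

Measured compounds:
compound 1 `COc1cc(F)c(NC(=O)c2ccnc(O)c2)cc1Nc1nccc(-c2cn(C)c3ccccc23)n1` — 5920 nM
compound 2 `COc1cc(F)c(NC(=O)c2ccncc2OC)cc1Nc1nccc(-c2cn(C)c3ccccc23)n1` — 4120 nM
compound 3 `COc1cc(N(C)CCN(C)C)c(NC(=O)c2ccnc(O)c2)cc1Nc1nccc(-c2cn(C)c3ccccc23)n1` — 12000 nM

In a functional assay on NCI-H1975 cells (Homo sapiens) for antiproliferative activity, read by MTT assay, with a stated time of 72 h (a lower number here means a stronger inhibitor, a higher number a weaker inhibitor), compound 3 gives the highest of the three numbers. The cores of compound 1 and compound 3 differ by (2-(dimethylamino)ethyl)(methyl)amino in place of fluoro on an aromatic carbon, and that change gives a 2.0-fold higher number from compound 1 to compound 3 (0.31 log units; beyond the scatter).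

The change 3-methoxypyridin-4-yl in place of 2-hydroxypyridin-4-yl on a carbonyl carbon gives a 1.4-fold lower number from compound 1 to compound 2 (0.16 log units; within the scatter). Compound 4 `COc1cc(N(C)CCN(C)C)c(NC(=O)c2ccncc2OC)cc1Nc1nccc(-c2cn(C)c3ccccc23)n1` is not yet measured; it carries the same change on the core of compound 3, (3-methoxypyridin-4-yl in place of 2-hydroxypyridin-4-yl on a carbonyl carbon), and the place is described in the same words for both pairs, so it counts as the same change.

Going by the values given here, the expectation for compound 4 rests on the one earlier instance: the step from compound 3 to compound 4 is expected to be a 1.4-fold lower number from compound 3 to compound 4 (0.15 log units; within the scatter), close to a 1.4-fold lower number from compound 1 to compound 2 (0.16 log units; within the scatter), because compound 3 starts from 12000 nM. Compound 4 is therefore estimated at 8500 nM, with a range from 4000 nM to 18000 nM.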

Compound 4, half-maximal inhibitory concentration: 1010 nM
Compound 4: the middle estimate sits 8.4-fold (0.93 log units) above what was measured; the whole stated range lies above it.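

In this assay, 3-methoxypyridin-4-yl in place of 2-hydroxypyridin-4-yl on a carbonyl carbon gives a 12-fold lower number from compound 3 to compound 4 (1.07 log units; beyond the scatter), so the size of this step does not carry from one core to the other: the same change on two cores in this assay, a 1.4-fold lower number (0.16 log units; within the scatter) from compound 1 to compound 2 and a 12-fold lower number (1.07 log units; beyond the scatter) from compound 3 to compound 4, 8.3-fold (0.92 log units) apart, beyond the scatter of two such steps

The second change, (2-(dimethylamino)ethyl)(methyl)amino in place of fluoro on an aromatic carbon, gives a 4.1-fold lower number from compound 2 to compound 4 (0.61 log units; beyond the scatter), which runs opposite in direction to the step on the other core: the same change on two cores in this assay, a 2.0-fold higher number (0.31 log units; beyond the scatter) from compound 1 to compound 3 and a 4.1-fold lower number (0.61 log units; beyond the scatter) from compound 2 to compound 4, 8.3-fold (0.92 log units) apart, beyond the scatter of two such steps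

The two changes therefore do not act independently across these four compounds, but this single set of four does not show which feature of either group sets the gap, or whether the gap would hold on another core.

Open, as far as these compounds go, is whether 3-ethoxypyridin-4-yl or unsubstituted pyridin-4-yl would follow 3-methoxypyridin-4-yl on either core. Also open, from the compounds shown here alone, is whether a morpholine or a longer amine chain in place of fluoro would show the same dependence.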